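This account rests on a few compounds, and the source may have more. Where it says the series, first, only, none or still open, it means among the compounds named here.

Compound 1 `CC(C)(C)c1ccc(CNCCCNS(=O)(=O)c2cc(C(F)(F)F)cc(C(F)(F)F)c2)cc1` has a single measured neighbour: in a functional assay on A2780 cells (Homo sapiens) for inhibition, read by MTT assay, with a stated time of 72 h (on this read-out higher numbers stand for weaker inhibition of growth and lower numbers for stronger inhibition of growth), compound 1 gives 2900 nM, and compound 2 `O=S(=O)(NCCCNCC1COc2ccccc2O1)c1cc(C(F)(F)F)cc(C(F)(F)F)c1` gives 1500 nM, the two values lying within the scatter of each other, as the step of a 1.9-fold lower number from compound 1 to compound 2 (0.29 log units; within the scatter) shows. Compound 3 `COc1cccc(CNCCCNS(=O)(=O)c2cc(C(F)(F)F)cc(C(F)(F)F)c2)c1` differs from compound 1 by 3-methoxyphenyl in place of 4-(tert-butyl)phenyl on a saturated chain carbon bound to an amine nitrogen. Among the compounds with values here, only the step from compound 1 to compound 2 bears on this place, and it stayed within the scatter; no measured step involves a 3-methoxyphenyl group. For compound 3 no change beyond the scatter is therefore expected, a 1.2-fold higher number from compound 1 to compound 3 (0.08 log units; within the scatter). Compound 3 is estimated at 3500 nM, with a range from 1400 nM to 9000 nM.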

Compound 3, concentration for 50% growth inhibition: 1600 nM
For compound 3 the middle estimate is 2.2-fold (0.34 log units) above the measured one, within the range that was stated.
By their numbers in this assay, from the lowest: compounds 2, 3 and 1 (each within the scatter of the next).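

With 3-methoxyphenyl in place of 4-(tert-butyl)phenyl on a saturated chain carbon bound to an amine nitrogen, this assay gives a 1.8-fold lower number from compound 1 to compound 3 (0.26 log units; within the scatter), and in place of 2,3-dihydro-1,4-benzodioxin-2-yl it gives a 1.1-fold higher number from compound 2 to compound 3 (0.03 log units; within the scatter). All three groups at this place thus lie within the scatter of each other, even with a hydrogen-bond acceptor entering and fewer heavy atoms than in 4-(tert-butyl)phenyl. No measurement at hand accounts for this flat picture.

Going by these compounds, whether a carboxylic acid or an amine on this ring would give a step beyond the scatter stays open, as does the outcome of a longer chain in the shared core.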